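This account rests on a few compounds, and the source may have more. Where it says the series, first, only, none or still open, it means among the compounds named here.

Three compounds share one core and differ only in the group that sits on the amide-type nitrogen at the end of the chain. Compound 1 `CC(C)(C)C(=O)N(CCCCCCN1C[C@H](O)[C@@H](O)[C@H](O)[C@H]1CO)c1ccc(F)cc1F` carries one such group. In an ADME assay on Huh-7 cells (Homo sapiens) for cytotoxicity, read by MTT assay (a higher number here means that more compound is tolerated, a lower number that less compound is tolerated), compound 1 gives only a limit, > 500000 nM, not a number. Compound 2 `CC(C)(C)C(=O)N(CCCCCCN1C[C@H](O)[C@@H](O)[C@H](O)[C@H]1CO)C1CC1` carries a smaller ring there, and in this assay compound 2 gives "not determined" (no result reported). Compound 3 `CC(C)(C)C(=O)N(CCCCCCN1C[C@H](O)[C@@H](O)[C@H](O)[C@H]1CO)C1CCC1` carries a cyclobutyl group, and in this assay compound 3 gives "not determined" (no result reported). So compound 3 has no number of its own to stand on: of the three values shown, one sits at the limit of > 500000 nM in this assay, at which 1 of the 3 values shown sits, and the other two were not determined at all.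

Compound 4 `CC(C)(C)C(=O)N(CCCCCCN1C[C@H](O)[C@@H](O)[C@H](O)[C@H]1CO)C1CCCC1` is the next member of the row. It differs from compound 3 by cyclopentyl in place of cyclobutyl on an amide-type nitrogen. No measured step between any two of these compounds exists in this assay, so no size can be read off for this change; the expectation is a step of no size beyond the usual scatter, in no particular direction. On that basis compound 4 is expected to tolerate about 400000 nM in this assay, with a plausible range from 100000 nM to 800000 nM, and the result may well come back as a limit rather than a number.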

Compound 4, half-maximal cytotoxic concentration: > 500000 nM
Compound 4: a limit, no number (the forecaster's own chance of this, stated with the estimate: 70%); at least 1.2-fold (0.09 log units) between middle value and limit.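

In this assay, among the compounds shown here, compound 1 and compound 4 both give a limit rather than a number, so no step between them can be read: the limit of > 500000 nM in this assay, at which 2 of the 4 values shown sit.

The compounds shown leave open how much of any of these compounds the cells actually tolerate, and whether changing the group on the amide-type nitrogen alters that at all.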